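Swapping a Fluorophenyl for a Chlorophenyl on a Triazole Arm

This account rests on a few compounds, and the source may have more. Where it says the series, first, only, none or still open, it means among the compounds named here.

In a functional assay on 4T1 cells (Mus musculus) for cytotoxicity, read by MTT assay, with a stated time of 24 h (on this read-out lower numbers stand for stronger inhibition and higher numbers for weaker inhibition), compound 1 `COc1ccc(/C=C2\CN(C(=S)SCc3cn(Cc4ccc(F)cc4)nn3)C/C(=C\c3ccc(OC)cc3)C2=O)cc1` gives only a limit of the assay, > 100000 nM. Compound 3 `COc1ccc(/C=C2\CN(C(=S)SCc3cn(Cc4cccc(Cl)c4)nn3)C/C(=C\c3ccc(OC)cc3)C2=O)cc1` differs from compound 1 by one change, (3-chlorophenyl in place of 4-fluorophenyl on a saturated chain carbon bound to an aromatic nitrogen), and in this assay compound 3 gives 69700 nM. The step is an at least 1.4-fold lower number from compound 1 to compound 3 (0.15 log units; that floor lies within the scatter). For compound 1, the limit of > 100000 nM in this assay, at which 1 of the 3 values shown sits, is what sets that floor. Compound 2 `Cc1ccc(/C=C2\CN(Cc3cn(Cc4ccc(F)cc4)nn3)C/C(=C\c3ccc(C)cc3)C2=O)cc1` gives 57200 nM in this assay. The difference between the cores of compound 1 and compound 2 is not broken down here. Compound 4 `Cc1ccc(/C=C2\CN(Cc3cn(Cc4cccc(Cl)c4)nn3)C/C(=C\c3ccc(C)cc3)C2=O)cc1` is not yet measured and carries the same change on the core of compound 2, (3-chlorophenyl in place of 4-fluorophenyl on a saturated chain carbon bound to an aromatic nitrogen). Because the earlier step of an at least 1.4-fold lower number from compound 1 to compound 3 (0.15 log units; that floor lies within the scatter) reaches only a floor within the scatter, compound 4 is expected to sit near compound 2, with an expected step of a 1.1-fold lower number from compound 2 to compound 4 (0.06 log units; within the scatter). Compound 4 is estimated at 50000 nM in this assay, expected between 20000 nM and 100000 nM.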

Compound 4, half-maximal inhibitory concentration: 29300 nM
Estimate against measurement, compound 4: 1.7-fold (0.23 log units) above, within the range that was stated.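

In this assay, putting 3-chlorophenyl in place of 4-fluorophenyl on the core of compound 2 gives a 2.0-fold lower number from compound 2 to compound 4 (0.29 log units; within the scatter), a step too small to show a clear effect of the change on this core. The value of compound 1, > 100000 nM, is a limit of the assay, not a number. The same change on the two cores therefore cannot show whether it carries over at the same size: the same change on two cores in this assay, an at least 1.4-fold lower number (0.15 log units; that floor lies within the scatter) from compound 1 to compound 3 and a 2.0-fold lower number (0.29 log units; within the scatter) from compound 2 to compound 4; the limit leaves it open whether they differ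

4-Fluorophenyl and 3-chlorophenyl differ in both the halogen and its place on the ring, and the compounds shown do not separate the two. Also open, going by these compounds, is what 4-chlorophenyl, plain phenyl or a phenyl bearing a carboxylic acid would give on this arm.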